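Swapping Piperidin-4-yl for 2-Fluorophenyl: Expected Toxicity of Compound 4

The source may hold more compounds than are shown below. What is called first, only, known or untested is meant among the compounds shown, and "the series" means these compounds.

The measured compounds are few. Compound 1 `COc1ccc(-c2cnc(NC(=O)C3CCNCC3)n2C)cc1` gives in a toxicity assay on THP-1 cells (Homo sapiens) for inhibition (on this read-out higher numbers stand for lower toxicity in this test and lower numbers for higher toxicity in this test), only a limit, > 100000 nM. Compound 2 `Cn1c(-c2ccccc2F)cnc1NC(=O)c1ccc(F)cc1` likewise gives only a limit, > 100000 nM. Compound 3 `Cc1ccc(C(=O)Nc2ncc(-c3ccccc3)n2C)cc1` also reaches only a limit, > 50000 nM.

Compound 1 therefore stands at a limit of this assay rather than at a number, and it shares this with the others: the limit of > 100000 nM in this assay, at which 2 of the 3 values shown sit, while (the limit of > 50000 nM in this assay, at which 1 of the 3 values shown sits). Within the data shown here, no measured pair differing in one place is available, so no step size can be read from the data.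

The unmeasured compound 4 `COc1ccc(-c2cnc(NC(=O)c3ccccc3F)n2C)cc1` differs from compound 1 in one place: 2-fluorophenyl in place of piperidin-4-yl on a carbonyl carbon. Since every measured compound sits at a limit, the step from compound 1 to compound 4 is expected to be none beyond the scatter, a number no higher from compound 1 to compound 4 (the limit leaves the size open). Compound 4 is therefore expected to come out at about 100000 nM, somewhere between 40000 nM and 250000 nM, most likely again as a limit only.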

Compound 4, half-maximal cytotoxic concentration: > 100000 nM
Compound 4: no number, only a limit (the forecaster's own chance of this, stated with the estimate: 85%); the middle value lies on the limit itself.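

Among these compounds, compound 1 and compound 4 both reach only a limit, so no step between them can be read. The compounds shown leave open whether exchanging piperidin-4-yl for 2-fluorophenyl changes the outcome at all, and at what concentration any of these compounds would register as toxic in this assay.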